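This account rests on a few compounds, and the source may have more. Where it says the series, first, only, none or still open, it means among the compounds named here.

Compound 2, whose structure is `CCS(=O)(=O)N(Cc1ccc(-c2cccc(F)c2)cc1)[C@@H](C)C(=O)N[C@H](C#N)CC(N)=O`, gives a half-maximal inhibitory concentration of 3890 nM in an assay on isolated protein for inhibition of legumain (Homo sapiens), with stated times of 2 min and 60 min; a lower number here means a stronger inhibitor, a higher number a weaker inhibitor. Among the two compounds measured so far it has the lowest number; the nearest neighbour, compound 1 with the structure `C[C@H](C(=O)N[C@H](C#N)CC(N)=O)N(Cc1ccc(-c2cc(F)cc(F)c2)cc1)S(C)(=O)=O`, gives 9250 nM in this assay, a gap that lies beyond the usual scatter. For the measured compounds named here, compound 1 and compound 2 differ in two places at once, so no single step between them can be read off.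

Compound 3, with the structure `CC(C)CS(=O)(=O)N(Cc1ccc(-c2cccc(F)c2)cc1)[C@@H](C)C(=O)N[C@H](C#N)CC(N)=O`, has not yet been measured. It differs from compound 2 in one place: isopropyl in place of methyl on a saturated chain carbon bound to a sulfonyl sulfur, that is, ethylsulfonyl becomes isobutylsulfonyl. Without a measured step of this kind among the compounds at hand, the expected step from compound 2 to compound 3 is a modest one, a 1.3-fold lower number from compound 2 to compound 3 (0.11 log units; within the scatter), with no firm direction. Compound 3 is accordingly estimated at 3000 nM in this assay, within a range of 1000 nM to 10000 nM.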

Compound 3, half-maximal inhibitory concentration: 2270 nM
Compound 3: middle estimate off by 1.3-fold (0.12 log units), on the high side; low and high end bracket the measured number.
By their numbers in this assay, from the lowest: compounds 3 and 2 (each within the scatter of the next); then compound 1.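

In this assay, for the compounds shown here, the change from ethylsulfonyl to isobutylsulfonyl provides the first comparison in which only one place differs, and it gives a 1.7-fold lower number from compound 2 to compound 3 (0.23 log units; within the scatter). On this saturated chain carbon bound to a sulfonyl sulfur, isopropyl can therefore stand in place of methyl with no shift beyond the scatter, and the pair sets no order between the two compounds. Nothing measured here accounts for the size of this step. Going by these compounds, whether an amine, a carboxylic acid, a phenyl ring or a longer chain at this place would leave the number equally unmoved remains open. On these data alone, it is also open whether isopropyl in place of methyl would give a similar step on the core of compound 1.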